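Moving from a fluoro to a methoxy benzyl sulfone

This account rests on a few compounds, and the source may have more. Where it says the series, first, only, none or still open, it means among the compounds named here.

Values in a functional assay on K562 cells (Homo sapiens) for cytotoxicity, read by trypan blue exclusion, with a stated time of 96 h; on this read-out lower numbers stand for stronger inhibition and higher numbers for weaker inhibition:
- compound 1 `COc1cc(OC)c(/C=C/S(=O)(=O)Cc2ccc(F)c(N)c2)c(OC)c1`: 2500 nM
- compound 2 `COc1ccc(CS(=O)(=O)/C=C/c2c(OC)cccc2OC)c(N)c1`: 750 nM

Of these two compounds, compound 1 stands highest at 2500 nM. Compound 2 lies lower at 750 nM, a gap beyond the usual scatter, although the two differ in more than one place.

The next compound to be tested in this assay is compound 3 `COc1cc(OC)c(/C=C/S(=O)(=O)Cc2cc(N)ccc2OC)c(OC)c1`. It keeps the core of compound 1 but carries 5-amino-2-methoxyphenyl in place of 3-amino-4-fluorophenyl on a saturated chain carbon bound to a sulfonyl sulfur.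

For the measured compounds named here, no measured pair isolates this change, so any forecast rests on thin evidence. Compound 2, at 750 nM, also carries amino and methoxy groups on the ring attached through that chain carbon, which gives a loose hint towards a lower number. The expected step is a 2.5-fold lower number from compound 1 to compound 3 (0.40 log units; beyond the scatter), a modest estimated move towards stronger inhibition, with no change beyond the scatter also quite possible. For compound 3 the estimated value is 1000 nM, with an expected range from 150 nM to 5000 nM.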

Compound 3, half-maximal inhibitory concentration: 7500 nM
For compound 3 the middle estimate is 7.5-fold (0.88 log units) below the measured one, outside the stated range (above it).
By their numbers in this assay, from the lowest: compound 2; then compound 1; then compound 3.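

In this assay, for the compounds shown here, putting 5-amino-2-methoxyphenyl in place of 3-amino-4-fluorophenyl on a saturated chain carbon bound to a sulfonyl sulfur brings a 3.0-fold higher number from compound 1 to compound 3 (0.48 log units; beyond the scatter), the only step in this set that changes a single place. With the rest of compound 1 held constant, it shows that the number in this assay responds to the ring carried at this position, and that this exchange moves towards weaker inhibition, modestly but beyond the usual scatter. Nothing available accounts for the step, and the data cannot assign it to the loss of the fluoro group, the gain of the methoxy group or the different arrangement of the ring's groups.

Going by these compounds alone, the single exchange changes the ring's groups and their arrangement together, so the contribution of each remains open, and 3-amino-4-methoxyphenyl at this place would help to separate them. Also open, from the compounds shown here alone, are whether the same step would hold on the core of compound 2, and how a ring bearing a hydroxy group or a carboxylic acid would behave here.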